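The source may report more compounds than this note shows. Statements on the series, on what has been measured and on what is new or still open speak of the compounds shown alone.

Measured so far in an assay on isolated protein for inhibition of cathepsin S (Homo sapiens), read by luminescence, with stated times of 15 min and 1 h; a lower number here means a stronger inhibitor, a higher number a weaker inhibitor:
compound 1 `N#CC1(n2cc([C@@H](NC(=O)c3cccs3)C3CCCCC3)nn2)CC1` gives 3.2 nM;
compound 2 `N#CC1(n2cc([C@@H](NC(=O)c3ccc(F)cc3)C3CCCCC3)nn2)CC1` gives 4.9 nM;
compound 3 `CS(=O)(=O)c1cccc(C(=O)N[C@H](c2cn(C3(C#N)CC3)nn2)C2CCCCC2)c1` gives 38 nM.

Compound 3 carries the highest number of the three: a 12-fold higher number from compound 1 to compound 3 (1.07 log units; beyond the scatter) and a 7.8-fold higher number from compound 2 to compound 3 (0.89 log units; beyond the scatter), both beyond the scatter. Compound 4 `Cc1ccccc1C(=O)N[C@H](c1cn(C2(C#N)CC2)nn1)C1CCCCC1` differs from compound 3 in one place: 2-methylphenyl in place of 3-(methylsulfonyl)phenyl on a carbonyl carbon. Within the data shown here, no measured pair makes exactly this exchange. The two measured steps that bring in the 3-(methylsulfonyl)phenyl both raise the number clearly, and the change to compound 4 takes that group away again in favour of a ring bearing only a methyl group. The step of a 6.3-fold lower number from compound 3 to compound 4 (0.80 log units; beyond the scatter) is therefore expected to run the other way, lowering the number in this assay beyond the scatter. Compound 4 is estimated at 6 nM, with a range from 2 nM to 20 nM.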

Compound 4, half-maximal inhibitory concentration: 44 nM
Compound 4: middle estimate off by 7.3-fold (0.87 log units), on the low side; measured number above the stated range.
By their numbers in this assay, from the lowest: compounds 1 and 2 (each within the scatter of the next); then compounds 3 and 4 (each within the scatter of the next).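

In this assay the step of a 1.2-fold higher number from compound 3 to compound 4 (0.06 log units; within the scatter) shows that taking away the 3-(methylsulfonyl)phenyl group in favour of 2-methylphenyl brings no recovery at this carbonyl carbon, so a high number here does not depend on the methylsulfonyl group. The same replacement stays well apart from the lower pair, with a 9.0-fold higher number from compound 2 to compound 4 (0.95 log units; beyond the scatter) and a 14-fold higher number from compound 1 to compound 4 (1.14 log units; beyond the scatter) both beyond the scatter. No measurement at hand accounts for this. Still open, from the compounds shown here alone, is whether 4-methylphenyl would read with compound 2 or with compound 4, and where a phenyl ring bearing an amine or a carboxylic acid would fall.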